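The compounds below may be only part of what the source reports. "The series", "measured", "known", "first", "only" and "open" are said of these compounds alone.

Three compounds that share one core and a piperidin-1-yl group, and differ only in the chain on the oxygen, have been measured in a functional assay on MES-SA cells (Homo sapiens) for inhibition, with a stated time of 72 h, in the presence of a further agent that is not named here; a lower number here means a stronger inhibitor, a higher number a weaker inhibitor: compound 1 `CCOCc1cc(CN2CCCCC2)c(O)c2ncccc12` gives 9120 nM, compound 2 `CCCOCc1cc(CN2CCCCC2)c(O)c2ncccc12` gives 3550 nM and compound 3 `CC(C)OCc1cc(CN2CCCCC2)c(O)c2ncccc12` gives 5750 nM. Compound 3 cannot be told apart from either of the others, since a 1.6-fold lower number from compound 1 to compound 3 (0.20 log units; within the scatter) and a 1.6-fold higher number from compound 2 to compound 3 (0.21 log units; within the scatter).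

Compound 4 `CC1CCN(Cc2cc(COC(C)C)c3cccnc3c2O)CC1` keeps the chain of compound 3 and changes the other end of the molecule: methyl in place of hydrogen on a saturated ring carbon. This is methyl in place of hydrogen on a saturated ring carbon, turning piperidin-1-yl into 4-methylpiperidin-1-yl. Going by the values given here, no measured step touches that ring. Among the compounds with values here, the only guides are the methyl additions on the chain, which are distant analogies: a 2.6-fold lower number from compound 1 to compound 2 (0.41 log units; beyond the scatter), a modest change, while a 1.6-fold lower number from compound 1 to compound 3 (0.20 log units; within the scatter). On that thin evidence, a small move is expected, a 1.4-fold lower number from compound 3 to compound 4 (0.16 log units; within the scatter), and it may not clear the scatter. For compound 4 the estimated value is 4000 nM, with an expected range of 1700 nM to 9000 nM.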

Compound 4, half-maximal inhibitory concentration: 3020 nM
Compound 4: middle estimate off by 1.3-fold (0.12 log units), on the high side; the range from low to high includes it.
By their numbers in this assay, from the lowest: compounds 4, 2, 3 and 1 (each within the scatter of the next, the first and the last beyond it).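

Replacing piperidin-1-yl with 4-methylpiperidin-1-yl, which puts the methyl three ring bonds from the ring nitrogen, gives a 1.9-fold lower number from compound 3 to compound 4 (0.28 log units; within the scatter) in this assay. Going by these compounds alone, the earlier compounds varied only the chain on the oxygen, so this is the only reading of the saturated ring, and it shows that this methyl is accepted there without a shift that can be told from the scatter. No supporting measurement is available to explain this result.

The compounds shown leave open whether the same methyl would read alike alongside the propyl chain of compound 2, since the ring change is seen only with the isopropyl chain. They also leave open what a morpholine, a 4-hydroxypiperidine or a larger group at this ring position would give.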